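The compounds below may be only part of what the source reports. "The series", "measured", "known", "first", "only" and "open" are said of these compounds alone.

In a physicochemical assay for lipophilicity, read by HPLC, at pH 7.4 (a higher number here means a more lipophilic compound, a lower number a more polar compound), compound 1 (`Cc1ccc(-c2cc(-c3ccc(S(C)(=O)=O)cc3)cnc2N)cn1`) gives 1.8 and compound 2 (`CS(=O)(=O)c1ccc(-c2cnc(N)c(-c3ccc(CO)nc3)c2)cc1`) gives 1.2 on the shared core. Compound 3 (`CS(=O)(=O)c1ccc(-c2cnc(N)c(-c3ccc(C(F)(F)F)cc3)c2)cc1`) reads 3.4 as the highest of the three, with compound 1 nearest and compound 2 furthest, both beyond the scatter.

Compound 4 (`CS(=O)(=O)c1ccc(-c2cnc(N)c(-c3ccc(C#N)cc3)c2)cc1`) differs from compound 3 in one place (cyano in place of trifluoromethyl on an aromatic carbon), with cyano in place of trifluoromethyl on an aromatic carbon, para to a large group. Within the data shown here, only one measured step changes a single place, a number 0.60 log units lower from compound 1 to compound 2 (beyond the scatter) with hydroxy in place of hydrogen on a saturated chain carbon bound to an aromatic carbon. Among the measured compounds shown here, that modest step involves neither trifluoromethyl nor cyano, so it bears on this change only loosely, and no measured step swaps these two groups.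

The expectation therefore rests mainly on the position of compound 3 at 3.4 far above compound 1 at 1.8 and on the structural change itself. A fall beyond the scatter and larger than the measured step is expected, and the estimated step is a number 1.20 log units lower from compound 3 to compound 4 (beyond the scatter) in size. For compound 4 the estimate is 2.2 with an expected range from 1.8 to 2.6 in this assay once measured.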

Compound 4, distribution coefficient: 2.4
For compound 4 the middle estimate is 0.20 log units below the measured one, and the stated range covers the measured number.
By their numbers in this assay, from the lowest: compound 2; then compound 1; then compound 4; then compound 3.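

In this assay, among these compounds, the exchange of trifluoromethyl for cyano on an aromatic carbon, para to a large group, gives a number 1.00 log units lower from compound 3 to compound 4 (beyond the scatter), the only measured step in which one group on this six-membered aromatic ring of carbon only replaces another. Against the two other aromatic groups, 4-cyanophenyl in place of 6-(hydroxymethyl)pyridin-3-yl gives a number 1.20 log units higher from compound 2 to compound 4 (beyond the scatter), and 4-cyanophenyl in place of 6-methylpyridin-3-yl gives a number 0.60 log units higher from compound 1 to compound 4 (beyond the scatter), so compound 4 reads above both while still standing below compound 3, although each of these two steps alters the ring and its substituent together and cannot divide the difference between them. Nothing available here accounts for the size of any of these steps.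

The compounds shown leave open how much of the two larger aromatic-group steps belongs to the ring itself and how much to the group it carries, since cyano and trifluoromethyl appear only on the carbon ring. They also leave open how an amine, a carboxylic acid or a longer chain at this same place would read in this assay relative to compound 4.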